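A few compounds are considered here, and "the series" means these few. Any claim that something is new, unique, unknown or untested is made for them only; others in the source may bear on it.

Measured compounds in a functional assay on M21 cells (Homo sapiens) for cytotoxicity, read by sulforhodamine B assay, with a stated time of 48 h; on this read-out higher numbers stand for weaker inhibition and lower numbers for stronger inhibition:
compound 1, `CCCc1ccccc1OS(=O)(=O)c1cccc(NC(=O)NCCCCl)c1`, 15000 nM
compound 2, `CCNC(=O)Nc1cccc(S(=O)(=O)Oc2ccccc2C)c1`, 51000 nM
compound 3, `CCNC(=O)Nc1cccc(S(=O)(=O)Oc2ccccc2CC)c1`, 30000 nM

Compound 3 stands second highest of the three numbers in this assay. Its nearest neighbour is compound 2, whose value lies within the scatter of it, and its furthest is compound 1, whose value also lies within the scatter.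

Compound 4, `CCCc1ccccc1OS(=O)(=O)c1cccc(NC(=O)NCC)c1`, is not yet measured. It differs from compound 3 by methyl in place of hydrogen on a saturated chain carbon, two bonds along the chain from an aromatic carbon; read one bond further out, the change is ethyl to propyl on the chain bound to the aromatic carbon.

Among the compounds with values here, only one measured step bears on this change: a 1.7-fold lower number from compound 2 to compound 3 (0.23 log units; within the scatter), a methyl-to-ethyl lengthening of the same chain, which stayed within the scatter. Within the data shown here, compound 1, which already carries the propyl chain but a different urea substituent, shows a number close to that of compound 3; no single step joins these two, so their values are noted only as they stand.

On this basis a further lengthening of the chain is expected to give at most a small step in this assay, if any, and more likely in the lower direction, so compound 4 is estimated at 20000 nM, ranging from 8000 nM to 50000 nM, which means an expected step of a 1.5-fold lower number from compound 3 to compound 4 (0.18 log units; within the scatter).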

Compound 4, half-maximal inhibitory concentration: 25000 nM
Beside the measured number, compound 4's estimate is 1.3-fold (0.10 log units) below it; low and high end bracket the measured number.
By their numbers in this assay, from the lowest: compounds 1, 4, 3 and 2 (each within the scatter of the next, the first and the last beyond it).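

In this assay, the change from ethyl to propyl on the chain bound to the aromatic carbon stays within the scatter (a 1.2-fold lower number from compound 3 to compound 4 (0.08 log units; within the scatter)), as the earlier change from methyl to ethyl did. Taken across both changes, the chain now gives the first step at this position that passes the scatter, though only modestly (a 2.0-fold lower number from compound 2 to compound 4 (0.31 log units; beyond the scatter)), so the effect of chain length appears only across the whole span from methyl to propyl. With the propyl chain held in place, hydrogen in place of chloromethyl on a saturated chain carbon, two bonds along the chain from an amide-type nitrogen, leaves the number within the scatter (a 1.7-fold higher number from compound 1 to compound 4 (0.22 log units; within the scatter)), so that change shows no readable effect here.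

As far as these compounds go, whether a longer chain such as butyl, a branched chain such as isopropyl, or an amine at the end of the chain would carry the number further in either direction remains open. Nothing in the material shown offers an explanation for the size of these steps.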